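Methoxy in Place of Fluoro on the Aryl Nitrogen Substituent

The source may report more compounds than this note shows. Statements on the series, on what has been measured and on what is new or still open speak of the compounds shown alone.

Compound 1 `COc1ccccc1N1CCN(CCCNC(=O)NN(Cc2cccc(F)c2)c2ccc(F)cc2)CC1` is the reference point. Among the compounds with values here, in an assay on CHO cells for displacement of a labelled ligand from D(4) dopamine receptor (Homo sapiens), read by radioligand binding (a higher number here means a weaker inhibitor, a lower number a stronger inhibitor), compound 1 gives 3.8 nM, the lowest of the two numbers known, with compound 2 `COc1ccccc1N1CCN(CCCNC(=O)NN(Cc2ccc(-c3ccccc3)cc2)c2ccc(F)cc2)CC1` nearest at 5.9 nM. Within the data shown here, the one measured step, a 1.6-fold higher number from compound 1 to compound 2 (0.19 log units; within the scatter), exchanges the group on the saturated chain carbon bound to the ring nitrogen and stays within the scatter. Compound 3 `COc1ccc(N(Cc2cccc(F)c2)NC(=O)NCCCN2CCN(c3ccccc3OC)CC2)cc1` differs from compound 1 at another place: methoxy in place of fluoro on an aromatic carbon, on an aromatic carbon of a six-membered aromatic ring of carbon only, para to a large group. Among the measured compounds shown here, no measured step touches this ring, so the only guide is the tolerance of the core toward change seen in a 1.6-fold higher number from compound 1 to compound 2 (0.19 log units; within the scatter). Compound 3 is therefore expected to stay close to its parent, with an estimated step of a 1.3-fold higher number from compound 1 to compound 3 (0.12 log units; within the scatter). The estimate for compound 3 in this assay is 5 nM, between 2 nM and 15 nM.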

Compound 3, inhibition constant: 6.2 nM
Beside the measured number, compound 3's estimate is 1.2-fold (0.09 log units) below it; low and high end bracket the measured number.
By their numbers in this assay, from the lowest: compounds 1, 2 and 3 (each within the scatter of the next).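

In this assay, within the data shown here, the step to 4-methoxyphenyl from 4-fluorophenyl, a 1.6-fold higher number from compound 1 to compound 3 (0.21 log units; within the scatter), gives the first reading at this ring, which the earlier step on the other nitrogen substituent did not touch. On an aromatic carbon para to a large group, methoxy with its added hydrogen-bond acceptor thus stands in for fluoro without a change beyond the scatter, so compounds 1, 2 and 3 all remain within the scatter of one another at both places varied so far. Nothing measured here accounts for this result.

The compounds shown leave open whether this tolerance at the same position extends to an amine, a carboxylic acid or a trifluoromethyl group. They also leave open whether a hydrogen there, or methoxy at another carbon of the ring, would give a similar number.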